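4-methylpiperazin-1-yl to phenyl on a carbonyl carbon

The source may report more compounds than this note shows. Statements on the series, on what has been measured and on what is new or still open speak of the compounds shown alone.

In a functional assay on HEK239 cells (Homo sapiens) for inhibition, read by ELISA, with a stated time of 24 h (a higher number here means a weaker inhibitor of growth, a lower number a stronger inhibitor of growth), compound 1 `CO/N=C/C=C/c1ccccc1OC(=O)c1ccccc1` reads > 100000 nM as a limit of the assay and not a number. Compound 2 `COc1ccccc1/C=C/C(=O)NO` gives 16800 nM as a measured number. Compound 3 `CN1CCN(C(=O)ONC(=O)/C=C/c2ccccc2OC(=O)c2ccccc2)CC1` gives 89300 nM as the higher of the two measured numbers, with a gap to compound 2 beyond the scatter. Compound 4 `O=C(/C=C/c1ccccc1OC(=O)c1ccccc1)NOC(=O)c1ccccc1` has phenyl in place of 4-methylpiperazin-1-yl on a carbonyl carbon relative to compound 3. Among the compounds with values here, no measured step of this kind is available, so the value of compound 3 serves as the anchor. The estimated step of a 1.3-fold lower number from compound 3 to compound 4 (0.11 log units; within the scatter) is expected to stay within the scatter. Compound 4 is expected near 70000 nM with 28000 nM to 100000 nM as the estimated range.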

Compound 4, concentration for 50% growth inhibition: 3200 nM
Beside the measured number, compound 4's estimate is 22-fold (1.34 log units) above it, outside the stated range (below it).
By their numbers in this assay, from the lowest: compound 4; then compound 2; then compound 3. At a limit, above all of these: compound 1.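

In this assay, phenyl in place of 4-methylpiperazin-1-yl on a carbonyl carbon gives a 28-fold lower number from compound 3 to compound 4 (1.45 log units; beyond the scatter) with no other change to the structure. Within the data shown here, the earlier compounds offered no pair differing in one place, so this is the first evidence that the group on this carbonyl carbon strongly affects growth inhibition.

As far as these compounds go, whether another group would match phenyl remains open, for example a methyl, a dimethylamino group or a substituted phenyl on the same carbonyl carbon. Nothing in the data shown bears on the cause of this step.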